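Ester to Amide on a Shared Core

The source may hold more compounds than are shown below. What is called first, only, known or untested is meant among the compounds shown, and "the series" means these compounds.

Compound 1 `CCOC(=O)c1c(N/N=C2/C(=O)NN=C2N)sc2c1CCCC2` gives 60% in a functional assay on Ehrlich cells (Mus musculus) for cytotoxicity, tested at 25 ug/mL (a lower number here means a weaker effect, a higher number a stronger effect of the compound at the concentration tested), the higher of the two numbers measured. Compound 2 `CCOC(=O)c1c(N/N=C2/C(=O)NN=C2C)sc2c1CCCC2` gives 43%, and the step of a number 17 percentage points lower from compound 1 to compound 2 (beyond the scatter) rests on a change at a different place than the one considered here. Compound 3 `NC(=O)c1c(N/N=C2/C(=O)NN=C2N)sc2c1CCCC2` differs from compound 1 by amino in place of ethoxy on a carbonyl carbon. Within the data shown here, no measured step touches the carbonyl carbon, so nothing measured bears directly on this change, and a step in this assay within the scatter is expected, with no clear direction. Compound 3 is therefore estimated at 55%, between 35% and 75%, the expected step being a number 5 percentage points lower from compound 1 to compound 3 (within the scatter).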

Compound 3, a percentage reported as activity, at one concentration (the size of the read-out at that concentration, not a potency): 65%
The estimate for compound 3 lay 10 percentage points below the measured number; measured number inside the range.
By their numbers in this assay, from the lowest: compound 2; then compounds 1 and 3 (each within the scatter of the next).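

In this assay, amino in place of ethoxy on the carbonyl carbon gives a number 5 percentage points higher from compound 1 to compound 3 (within the scatter), so on this core the ethoxycarbonyl group can give way to carbamoyl without a change beyond the scatter. This position therefore tolerates the exchange, whereas the methyl in place of amino step elsewhere gave a number 17 percentage points lower from compound 1 to compound 2 (beyond the scatter). No measurement on hand explains this result. Going by these compounds, whether a carboxylic acid or a longer ester chain on the carbonyl carbon would hold the read-out remains open, as does whether carbamoyl would do so alongside methyl in place of amino.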